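This account rests on a few compounds, and the source may have more. Where it says the series, first, only, none or still open, it means among the compounds named here.

In an ADME assay on HEL cells (Homo sapiens) for cytotoxicity, with a stated time of 3 days (on this read-out lower numbers stand for higher toxicity in this test and higher numbers for lower toxicity in this test), compound 1 `Cc1cc(N2CCN(C)CC2)cn2c(CSCCc3ccccc3)cnc12` gives 20 ug/mL. Compound 3 `Cc1cc(-n2cccc2)cn2c(CSCc3ccccc3)cnc12` gives 20 ug/mL in this assay. Compound 2 `Cc1cc(N2CCCC2=O)cn2c(CSCCc3ccccc3)cnc12` gives > 100 ug/mL in this assay, and that entry is a limit of the test rather than a number. By contrast with the other two, compound 2 thus sits at the limit of > 100 ug/mL in this assay, at which 1 of the 3 values shown sits, so its entry is a bound of the test rather than a number, and its true value could lie anywhere beyond it. Within the data shown here, the one measured step that touches compound 2 is an at least 5.0-fold higher number from compound 1 to compound 2 (0.69 log units; beyond the scatter).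

The unmeasured compound 4 `Cc1cc(Sc2ccc(Cl)cc2)cn2c(CSCCc3ccccc3)cnc12` differs from compound 2 in a single place: (4-chlorophenyl)sulfanyl in place of 2-oxopyrrolidin-1-yl on an aromatic carbon. No measured pair exchanges a 2-oxopyrrolidin-1-yl group for a (4-chlorophenyl)sulfanyl group, so the size of this particular change cannot be read from the numbers shown. What the numbers do show is that compound 2, carrying the 2-oxopyrrolidin-1-yl group, sits at the limit, whereas compound 1 and compound 3, which carry other groups at this carbon, both give measured numbers in this assay. The expected step is therefore an at least 3.3-fold lower number from compound 2 to compound 4 (0.52 log units; beyond the scatter), back toward the measured numbers of the other two compounds, though a result at the limit remains quite possible.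

The estimate for compound 4 is 30 ug/mL, with a range from 10 ug/mL to 100 ug/mL.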

Compound 4, minimum cytotoxic concentration: 20 ug/mL
For compound 4 the middle estimate is 1.5-fold (0.18 log units) above the measured one; low and high end bracket the measured number.
By their numbers in this assay, from the lowest: compounds 1, 3 and 4 (each within the scatter of the next). At a limit, above all of these: compound 2.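

In this assay, putting (4-chlorophenyl)sulfanyl in place of 2-oxopyrrolidin-1-yl on this aromatic carbon gives an at least 5.0-fold lower number from compound 2 to compound 4 (0.69 log units; beyond the scatter), which means higher toxicity in this test. Putting the same group in place of 4-methylpiperazin-1-yl gives no change at the digits printed from compound 1 to compound 4 (within the scatter), so these two groups cannot be told apart in this test, and compound 2 is the one that stands apart among the three compounds that differ only at this carbon. The entry for compound 2 is a limit of the test rather than a number, so its step marks only the smallest gap that fits the data: the limit of > 100 ug/mL in this assay, at which 1 of the 4 values shown sits.

The compounds shown leave open whether the low toxicity in this test belongs to 2-oxopyrrolidin-1-yl alone or would also appear with other groups at this carbon, such as a pyrrolidin-1-yl ring without the carbonyl, a simple open-chain amide or a carboxylic acid. They also leave open how far beyond its limit the true value of compound 2 lies, and so how large the real difference from compound 1 and compound 4 is.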